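The compounds below may be only part of what the source reports. "The series", "measured", "known", "first", "only" and "open" are said of these compounds alone.

In a functional assay on HepG2 cells (Homo sapiens) for antiproliferative activity, read by MTT assay, with a stated time of 48 h (on this read-out higher numbers stand for weaker inhibition and lower numbers for stronger inhibition), the benzimidazole-bearing enone series spans a wide range. Compound 1 `O=C(/C=C/c1ccccn1)c1nc2ccccc2[nH]1` gives 340 nM, while compound 2 `O=C(/C=C/c1ccccc1Br)c1nc2ccccc2[nH]1`, which carries a bromophenyl instead of the pyridyl arm, gives 29200 nM. Compound 2 therefore holds the highest of the two numbers reported, and the gap between it and compound 1 lies beyond the scatter. Compound 3 `O=C(/C=C/c1ccccn1)c1nc2ccccc2o1` reports only a limit in this assay, > 100000 nM, and no number; this is the limit of > 100000 nM in this assay, at which 1 of the 3 values shown sits.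

Compound 4 `Cc1ccccc1/C=C/C(=O)c1nc2ccccc2[nH]1` has not yet been tested in this assay. It differs from compound 2 in one place: methyl in place of bromo on an aromatic carbon. Among the compounds with values here, no pair among the measured compounds shows a step of this kind, so the size of the step from compound 2 to compound 4 has to be judged from the structures alone. A methyl group in place of a bromo group, each of a single heavy atom, changes neither ring count nor donor or acceptor count nor charge, and compound 2 starts from a weak position with 29200 nM. The expected step in this assay from compound 2 to compound 4 is therefore small, a 1.2-fold lower number from compound 2 to compound 4 (0.07 log units; within the scatter), in no clear direction and likely within the scatter. Compound 4 is accordingly estimated at 25000 nM, with a range from 8000 nM to 80000 nM.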

Compound 4, half-maximal inhibitory concentration: 6710 nM
Compound 4: the middle estimate sits 3.7-fold (0.57 log units) above what was measured; the measured number lies below the stated range.
By their numbers in this assay, from the lowest: compound 1; then compound 4; then compound 2. At a limit, above all of these: compound 3.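

In this assay, methyl in place of bromo on an aromatic carbon of the six-membered aromatic ring of carbon only gives a 4.4-fold lower number from compound 2 to compound 4 (0.64 log units; beyond the scatter) and is the only step shown between compounds that differ in one place. It shows that this position is not silent: two groups of one heavy atom each, neither with a ring, a hydrogen-bond donor or acceptor, or a net charge, still lie apart by more than the scatter, although the step remains modest. Nothing measured in the data shown bears on why this step arises.

Going by these compounds, it remains open whether other groups at this place, such as an amine, a methoxy group or a longer chain, would move the number further, and in which direction. Within the data shown here, it is equally open whether the exchange of bromo for methyl would give a step of similar size on a core other than the one shared by compound 2 and compound 4.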